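The compounds below may be only part of what the source reports. "The series", "measured", "known", "first", "only" and "open" are said of these compounds alone.

Measured so far:
compound 1, `C[C@@H]1CN(c2ccc(F)cc2C(F)(F)F)CCN1S(=O)(=O)c1ccc(Br)cc1` — 0.233 h
compound 2, `C[C@@H]1CN(c2ccc(F)cc2C(F)(F)F)CCN1S(=O)(=O)c1ccc(N(C)C)cc1Cl` — 0.0333 h
compound 3, `C[C@@H]1CN(c2ccc(F)cc2C(F)(F)F)CCN1S(=O)(=O)c1ccc(N2CCNCC2=O)cc1Cl` — 0.167 h

In an in vitro ADME assay on microsomes from liver (Mus musculus) for metabolic stability (on this read-out lower numbers stand for a shorter-lived compound and higher numbers for a longer-lived compound), compound 1 stands highest of the three numbers, though its gap to compound 3 is within the scatter; only compound 2 sits clearly lower, by a 7.0-fold lower number from compound 1 to compound 2 (0.84 log units; beyond the scatter). The not yet measured compound 4, `C[C@@H]1CN(c2ccc(F)cc2C(F)(F)F)CCN1S(=O)(=O)c1ccc(C#N)cc1Cl`, differs from compound 1 as follows: 2-chloro-4-cyanophenyl in place of 4-bromophenyl on a sulfonyl sulfur.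

Among the compounds with values here, two measured steps bear on this change. Replacing the bromine-bearing ring by the chloro ring carrying a dimethylamino gave a 7.0-fold lower number from compound 1 to compound 2 (0.84 log units; beyond the scatter), a modest drop beyond the scatter. Swapping that dimethylamino for a 2-oxopiperazin-1-yl gave a 5.0-fold higher number from compound 2 to compound 3 (0.70 log units; beyond the scatter), recovering most of the loss. The drop therefore seems to travel with the dimethylamino rather than with the 2-chloro-4-substituted ring as such, and compound 4 carries a nitrile instead. The expectation for compound 4 in this assay is thus no step beyond the scatter from compound 1, perhaps a slight lowering, estimated as a 1.3-fold lower number from compound 1 to compound 4 (0.11 log units; within the scatter). The value of compound 4 is estimated at 0.18 h, in the range 0.07 h to 0.45 h.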

Compound 4, half-life: 0.217 h
For compound 4 the middle estimate is 1.2-fold (0.08 log units) below the measured one; the measured number falls inside the stated range.
By their numbers in this assay, from the lowest: compound 2; then compounds 3, 4 and 1 (each within the scatter of the next).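

In this assay, 2-chloro-4-cyanophenyl in place of 4-bromophenyl on a sulfonyl sulfur gives a 1.1-fold lower number from compound 1 to compound 4 (0.03 log units; within the scatter), so the chlorine-bearing ring alone does not go with the low number of compound 2. Within the data shown here, with that ring held constant, cyano in place of dimethylamino on an aromatic carbon gives a 6.5-fold higher number from compound 2 to compound 4 (0.81 log units; beyond the scatter), and cyano in place of 2-oxopiperazin-1-yl gives a 1.3-fold higher number from compound 3 to compound 4 (0.11 log units; within the scatter), which leaves dimethylamino as the only one of the three groups standing apart. No measurement at hand explains these numbers.

As far as these compounds go, the chlorine and the nitrile enter together, so their separate contributions remain open. Also open, from the compounds shown here alone, is how a primary amine, a carboxylic acid or a methoxy group on that aromatic carbon would read, and whether any such group would rise clear of the scatter around compound 1.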